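Reversing the double bond of compound 2

The source may report more compounds than this note shows. Statements on the series, on what has been measured and on what is new or still open speak of the compounds shown alone.

In a functional assay on NB-4 cells (Homo sapiens) for inhibition, read by XTT assay, with a stated time of 48 h (a lower number here means a stronger inhibitor, a higher number a weaker inhibitor), compound 1 (`CC(=O)OC/C(=C\c1ccccc1F)C(=O)c1ccccc1`) gives 5800 nM while compound 2 (`CC(=O)OC/C(=C\c1ccc(Cl)cc1Cl)C(=O)c1ccccc1`) gives 6600 nM and compound 3 (`CC(=O)OC/C(=C/c1ccccc1F)C(=O)c1ccccc1`) gives 8300 nM on the same read-out. Compound 2 therefore sits in a close group: its value lies within the usual scatter of both others, and these numbers cannot rank it against them.

Its partner, compound 4 (`CC(=O)OC/C(=C/c1ccc(Cl)cc1Cl)C(=O)c1ccccc1`), has not yet been measured. The difference between the two reads the two compounds have the same atoms and bonds and differ only in configuration as drawn: 1 of 1 stereo elements differ; a double bond is drawn E in compound 2 and Z in compound 4 and so concerns the double bond alone, with no group leaving or entering.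

Among the compounds with values here, one measured step bears on this change. It is a 1.4-fold higher number from compound 1 to compound 3 (0.16 log units; within the scatter) and it is a close parallel, resting on the fact that compounds 1 and 3 differ only in the configuration as drawn with the double bond drawn E in compound 1 and Z in compound 3. That single step stays within the scatter, so no change beyond the scatter is expected on going from compound 2 to compound 4, only perhaps a slight drift in the same direction, towards a higher number.

The expected size of the change is a 1.2-fold higher number from compound 2 to compound 4 (0.07 log units; within the scatter) and it is estimated to stay inside the scatter. The estimate for compound 4 is 7800 nM with an expected range of 4000 nM to 15000 nM for the coming measurement.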

Compound 4, half-maximal inhibitory concentration: 12600 nM
Estimate against measurement, compound 4: 1.6-fold (0.21 log units) below, within the range that was stated.
By their numbers in this assay, from the lowest: compounds 1, 2, 3 and 4 (each within the scatter of the next, the first and the last beyond it).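

In this assay, reversing the double bond in the chlorine-bearing pair gives a 1.9-fold higher number from compound 2 to compound 4 (0.28 log units; within the scatter), so a second pair now stands beside the fluorine-bearing one, which gave a 1.4-fold higher number from compound 1 to compound 3 (0.16 log units; within the scatter). The earlier compounds shown here showed this change with a single fluorine substituent only; it now stays within the scatter with two chlorine substituents as well, and neither step can rank the two compounds it joins. No group leaves or enters in this new step, so it speaks to configuration alone: the fact that compounds 2 and 4 differ only in the configuration as drawn

All four compounds keep the acetate ester and the phenyl ketone, so they leave open whether the reversal would still stay within the scatter with an amine, a carboxylic acid or a longer chain in place of the acetate. They also leave open how the two configurations would compare with a methoxy or a nitrile group on the aryl group in place of the halogens, since fluorine and chlorine are the only substituents shown there.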